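The source may report more compounds than this note shows. Statements on the series, on what has been measured and on what is new or still open speak of the compounds shown alone.

Measured compounds in a functional assay on RPMI-8226 cells (Homo sapiens) for inhibition, read by sulforhodamine B assay, with a stated time of 48 h; on this read-out lower numbers stand for stronger inhibition of growth and higher numbers for weaker inhibition of growth:
Compound 1 `O=C(Nc1cccc(-n2cc(-c3ccncc3)c(-c3ccc(Cl)c(O)c3)n2)c1)Nc1cccc(C(F)(F)F)c1` gives > 32500 nM.
Compound 2 `COc1cc(-c2nn(-c3cccc(NC(=O)Nc4cc(C(F)(F)F)cc(C(F)(F)F)c4)c3)cc2-c2ccncc2)ccc1Cl` gives > 50000 nM.
Compound 3 `COc1cc(-c2nn(-c3cccc(NC(=O)c4cccc(C(F)(F)F)c4)c3)cc2-c2ccncc2)ccc1Cl` gives 26600 nM.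

The value for compound 1 is a limit of the assay, not a number. The value for compound 2 is likewise a limit. Among the measured compounds shown here, compound 3 therefore carries the only number of the three, and it is a weak one. Compound 4 `COc1cc(-c2nn(-c3cccc(NC(=O)Nc4ccc(Cl)c(Cl)c4)c3)cc2-c2ccncc2)ccc1Cl` differs from compound 3 by (3,4-dichlorophenyl)amino in place of 3-(trifluoromethyl)phenyl on a carbonyl carbon, which makes that part of compound 4 resemble compound 1 and compound 2, both of which reached only limits. For the measured compounds named here, no measured step matches this change. Compound 4 is expected to sit at or beyond the weak end, with the expected step of a 1.4-fold higher number from compound 3 to compound 4 (0.15 log units; within the scatter) pointing toward weaker growth inhibition and a fair chance that compound 4 is expected to reach only a limit. The estimate for compound 4 is 38000 nM, in the range 15000 nM to 90000 nM.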

Compound 4, concentration for total growth inhibition: 3260 nM
Compound 4: middle estimate off by 12-fold (1.07 log units), on the high side; the whole stated range lies above it.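

In this assay, the group on this carbonyl carbon turns out to matter: the change gives an 8.2-fold lower number from compound 3 to compound 4 (0.91 log units; beyond the scatter), a shift beyond the usual scatter. The change brings in the amino nitrogen and the dichlorinated ring together, so this one step cannot separate their contributions. Compound 2 also has an amino nitrogen at this place but a different ring, and it reaches only a limit of the assay: the limit of > 50000 nM in this assay, at which 1 of the 4 values shown sits.

On these data alone, whether the ring needs both chlorines stays open. So does whether a cyclohexyl group or a carboxylic acid on that amino nitrogen would keep the gain.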